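The compounds below may be only part of what the source reports. "The series", "measured", "known", "first", "only" and "open" are said of these compounds alone.

Measured compounds:

Compound 1, `Clc1cccc(Cn2cc(COc3ccccc3)nn2)c1`, gives 14.6 ug/mL.
Compound 2, `Cc1ccc(OCc2cn(Cc3cccc(Cl)c3)nn2)cc1`, gives 36.7 ug/mL.
Compound 3, `O=[N+]([O-])c1ccc(Cn2cc(COc3ccc(Cl)cc3)nn2)cc1`, gives 31.1 ug/mL.

All three values come from an ADME assay on THP-1 cells (Homo sapiens) for inhibition, read by MTT assay, with a stated time of 48 h; on this read-out lower numbers stand for stronger inhibition of growth and higher numbers for weaker inhibition of growth. Compound 1 and compound 2 differ by one change, (methyl in place of hydrogen on an aromatic carbon), and that change made a 2.5-fold higher number from compound 1 to compound 2 (0.40 log units; beyond the scatter). Compound 3 sits at the second highest of the three numbers; against compound 2 it is within the scatter, against compound 1 it is beyond it. How the core of compound 3 differs from the core of compound 1 is not broken down here.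

Compound 4, `Cc1cc(OCc2cn(Cc3ccc([N+](=O)[O-])cc3)nn2)ccc1Cl`, has not yet been measured in this assay. It differs from compound 3 by methyl in place of hydrogen on an aromatic carbon. Among the measured compounds shown here, this is the same kind of change as the one from compound 1 to compound 2, but the surroundings are not the same: in compound 2 the entering methyl stands para to a large group, whereas in compound 4 it stands ortho to a chloro group and meta to a large group. For the measured compounds named here, only one earlier instance of this change is on hand, so the expectation rests on a single step.

On that basis, compound 4 is expected to give a higher number than compound 3, a step of about a 1.8-fold higher number from compound 3 to compound 4 (0.25 log units; within the scatter) in this assay, because the earlier change gave a 2.5-fold higher number from compound 1 to compound 2 (0.40 log units; beyond the scatter). The estimate for compound 4 in this assay is therefore 55 ug/mL, expected to lie between 25 ug/mL and 110 ug/mL.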

Compound 4, concentration for 50% growth inhibition: 27.9 ug/mL
Compound 4: the middle estimate sits 2.0-fold (0.29 log units) above what was measured; the measured number falls inside the stated range.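

In this assay, methyl in place of hydrogen on an aromatic carbon gave a 1.1-fold lower number from compound 3 to compound 4 (0.05 log units; within the scatter), so compound 4 cannot be told apart from compound 3, and the added methyl leaves no readable mark on this core. The change therefore did not carry over at the same size from one core to the other, and the two steps differ by more than their expected scatter: the same change on two cores in this assay, a 2.5-fold higher number (0.40 log units; beyond the scatter) from compound 1 to compound 2 and a 1.1-fold lower number (0.05 log units; within the scatter) from compound 3 to compound 4, 2.8-fold (0.45 log units) apart, beyond the scatter of two such steps This does not show what sets the two steps apart or how the change would behave on any other core, since only two instances are on hand and they differ both in the rest of the core and in the surroundings of the methyl, which in compound 4 stands ortho to a chloro group and meta to a large group.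

The compounds shown leave open whether a methyl in the place it holds in compound 4 would give a step of similar size on the core of compound 1. They also leave open how an amine, a carboxylic acid or a longer chain such as ethyl would read in that same place on the 4-chlorophenyl group of compound 3.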